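Swapping phenyl for 2,2,2-trifluoroethyl on the shared core

The source may hold more compounds than are shown below. What is called first, only, known or untested is meant among the compounds shown, and "the series" means these compounds.

In a functional assay on MCF7 cells (Homo sapiens) for inhibition (a lower number here means a stronger inhibitor of growth, a higher number a weaker inhibitor of growth), compound 1 `COC(=O)c1ccsc1NC(=O)[C@@H]1CCCN1` gives > 250 ug/mL as a limit. Compound 2 `O=C(Oc1ccccc1)c1ccsc1NC(=O)[C@@H]1CCCN1` gives > 250 ug/mL as a limit too. That leaves compound 2 with the limit of > 250 ug/mL in this assay, at which 2 of the 3 values shown sit, and no number to step from. Compound 3 `O=C1CC[C@@H](COC(=O)c2ccsc2NC(=O)[C@@H]2CCCN2)N1` gives 148 ug/mL as a number. Compound 4 `O=C(OCC(F)(F)F)c1ccsc1NC(=O)[C@@H]1CCCN1` differs from compound 2 by 2,2,2-trifluoroethyl in place of phenyl on an oxygen next to a carbonyl group with 2,2,2-trifluoroethyl in place of phenyl on an oxygen next to a carbonyl group. Changes on that oxygen give a step that the two limits leave unreadable from compound 1 to compound 2 and an at least 1.6-fold lower number from compound 1 to compound 3 (0.22 log units; that floor lies within the scatter) and an at least 1.6-fold lower number from compound 2 to compound 3 (0.22 log units; that floor lies within the scatter) so no readable step lies beyond the scatter. The expected step is a number no higher from compound 2 to compound 4 (the limit leaves the size open) and nothing beyond the scatter in this assay is expected. Compound 4 is estimated at 250 ug/mL with an expected range of 120 ug/mL to 500 ug/mL and is expected to may well come out only as a limit.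


Correction to the last prose sentence, whose wording above came out ungrammatical; it should read:

Compound 4 is estimated at 250 ug/mL with an expected range of 120 ug/mL to 500 ug/mL and may well come out only as a limit.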

Compound 4, concentration for 50% growth inhibition: 89.7 ug/mL
For compound 4 the middle estimate is 2.8-fold (0.45 log units) above the measured one, outside the stated range (below it).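

In this assay, within the data shown here, 2,2,2-trifluoroethyl in place of phenyl on an oxygen next to a carbonyl group gives what the earlier compounds did not, a step beyond the scatter, with an at least 2.7-fold lower number from compound 2 to compound 4 (0.44 log units; beyond the scatter). Trifluoromethyl in place of hydrogen also reads beyond the scatter, with an at least 2.7-fold lower number from compound 1 to compound 4 (0.44 log units; beyond the scatter), whereas trifluoromethyl in place of 5-oxopyrrolidin-2-yl stays within it, with a 1.6-fold lower number from compound 3 to compound 4 (0.22 log units; within the scatter). The two steps beyond the scatter are floors, not sizes: the limit of > 250 ug/mL in this assay, at which 2 of the 4 values shown sit.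

Still open, as far as these compounds go, is whether the gain extends to a longer fluorinated chain or to an amine on this oxygen.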